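Swapping naphthalenyl for sulfanylphenyl on a fused core

The source may hold more compounds than are shown below. What is called first, only, known or untested is meant among the compounds shown, and "the series" means these compounds.

Compound 1 `COc1ccc(-c2c3ccc4ccccc4c3nc3c2c(C)nc2c4ccccc4ccc32)cc1` gives 82.3 ug/mL in a functional assay, read by spectrophotometry, with a stated time of 15 min; a higher number here means a weaker inhibitor, a lower number a stronger inhibitor.
Compound 2 `Cc1nc2c3ccccc3ccc2c2nc3c(ccc4ccccc43)c(-c3cccc4ccccc34)c12` gives 64.3 ug/mL in this assay.
Compound 3 `Cc1nc2c3ccccc3ccc2c2nc3c(ccc4ccccc43)c(-c3ccccc3Cl)c12` gives 74.6 ug/mL in this assay.

All three compounds share the same six-ring core and differ only in the aryl group attached to it. Compound 2 carries the lowest of the three numbers, but both of its neighbours lie within the scatter: the step of a 1.3-fold lower number from compound 1 to compound 2 (0.11 log units; within the scatter) and the step of a 1.2-fold higher number from compound 2 to compound 3 (0.06 log units; within the scatter) are each too small to count as a real change.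

Compound 4 `Cc1nc2c3ccccc3ccc2c2nc3c(ccc4ccccc43)c(-c3ccccc3S)c12` is the next member, formed by the change (2-sulfanylphenyl in place of naphthalen-1-yl on an aromatic carbon). For the measured compounds named here, the step that bears most directly on it is the one from compound 2 to compound 3, where another single-ring aryl group replaced the naphthalen-1-yl group and the number barely moved. The step from compound 1 to compound 2 likewise shows that the aryl group has so far made little difference. Compound 4 is therefore expected to change by a 1.1-fold higher number from compound 2 to compound 4 (0.04 log units; within the scatter), which is no step beyond the scatter. Compound 4 is estimated at 70 ug/mL, with a range from 38 ug/mL to 130 ug/mL.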

Compound 4, half-maximal inhibitory concentration: 49.6 ug/mL
Compound 4: middle estimate off by 1.4-fold (0.15 log units), on the high side; measured number inside the range.
By their numbers in this assay, from the lowest: compounds 4, 2, 3 and 1 (each within the scatter of the next).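

In this assay the 2-sulfanylphenyl group, which brings a hydrogen-bond donor to this position opposite the ring nitrogen, gives a 1.3-fold lower number from compound 2 to compound 4 (0.11 log units; within the scatter) and so cannot be told apart from naphthalen-1-yl. Exchanging chloro for sulfanyl on the single ring gives a 1.5-fold lower number from compound 3 to compound 4 (0.18 log units; within the scatter) and the change from 4-methoxyphenyl, with a 1.7-fold lower number from compound 1 to compound 4 (0.22 log units; within the scatter) as its step, also shows no real difference, so all four aryl groups shown here give numbers that cannot be separated. No measurement shown here explains these small differences.

As far as these compounds go, whether an aryl group carrying an amine or a carboxylic acid, or a longer alkyl chain in place of the aryl group, would move the number beyond the scatter remains open. Also open, from the compounds shown here alone, is what replacing the methyl group on the shared core would do.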